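Moving the chlorine on the sulfur-linked benzyl group

The source may hold more compounds than are shown below. What is called first, only, known or untested is meant among the compounds shown, and "the series" means these compounds.

Compound 3 `CC1=C(C(=O)Nc2ccc([N+](=O)[O-])cc2)C(c2ccc(Br)cc2)N=C(SCc2ccccc2Cl)N1` gives 6.7% in a functional assay on the whole organism (artery, strain albino) with Rattus norvegicus as the target, with a stated time of 720 min, at a dose of 10 mg/kg by the oral route (a higher number here means more inhibition at the dose given (going by the name of the read-out), a lower number less inhibition), the lowest of the three numbers recorded. Compound 1 `CC1=C(C(=O)Nc2ccc(Br)cc2)C(c2ccc(Cl)cc2Cl)N=C(SCc2cccc(Cl)c2)N1` gives 11.3% in this assay, within the scatter of compound 3, while compound 2 `CC1=C(C(=O)Nc2ccc([N+](=O)[O-])cc2)C(c2ccc(Br)cc2)N=C(SCc2ccccc2)N1` gives 21.1%, beyond it. Compound 4 `CC1=C(C(=O)Nc2ccc([N+](=O)[O-])cc2)C(c2ccc(Br)cc2)N=C(SCc2cccc(Cl)c2)N1` differs from compound 3 by 3-chlorophenyl in place of 2-chlorophenyl on a saturated chain carbon bound to a sulfur. Among the measured compounds shown here, the only measured step is a number 14.4 percentage points lower from compound 2 to compound 3 (beyond the scatter); it concerns adding the chlorine, not shifting it, so it bears on the present change only loosely. For the measured compounds named here, compound 1, which also carries a 3-chlorobenzyl group, shows 11.3%, but no single step links it to compound 4. The expected step is a number 4.3 percentage points higher from compound 3 to compound 4 (within the scatter), within the scatter. Compound 4 is estimated at 11%, between 3% and 22%.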

Compound 4, a percentage reported as inhibition, in the whole organism at one dose (the size of the read-out at that dose, not a potency): 2.6%
Estimate against measurement, compound 4: 8.4 percentage points above, and the stated range ends above it.
By their numbers in this assay, from the lowest: compounds 4, 3, 1 and 2 (each within the scatter of the next, the first and the last beyond it).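

Moving the chlorine gives a number 4.1 percentage points lower from compound 3 to compound 4 (within the scatter) in this assay and so does not separate the 2-chlorobenzyl and 3-chlorobenzyl compounds. The 3-chlorobenzyl group also gives a number 18.5 percentage points lower from compound 2 to compound 4 (beyond the scatter) and thus, like the 2-chlorobenzyl group, sits lower than the unsubstituted benzyl group. No measurement at hand accounts for this.

Still open, as far as these compounds go, is whether an amine or a carboxylic acid on the benzyl ring in place of the chlorine would raise the number. The same holds for a longer chain in place of the benzyl group on the sulfur.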